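Moving a methyl group: what compound 4 may show

The source may hold more compounds than are shown below. What is called first, only, known or untested is meant among the compounds shown, and "the series" means these compounds.

- compound 1 `CC1(C)CCC[C@]2(C)[C@@H](CC[C@@](C)(O)/C=C/c3ccccc3)[C@](C)(O)CC[C@@H]12`: 3150 nM
- compound 2 `Cc1ccc(C)c(/C=C/[C@](C)(O)CC[C@@H]2[C@@]3(C)CCCC(C)(C)[C@@H]3CC[C@@]2(C)O)c1`: 3320 nM
- compound 3 `COc1cccc(OC)c1/C=C/[C@](C)(O)CC[C@@H]1[C@@]2(C)CCCC(C)(C)[C@@H]2CC[C@@]1(C)O`: 42000 nM

All three compounds were tested in a functional assay on A549 cells (Homo sapiens) for cytotoxicity, read by MTT assay, with a stated time of 48 h (on this read-out higher numbers stand for weaker inhibition and lower numbers for stronger inhibition), and differ only in the aryl group on the double-bonded chain carbon. Compound 2 sits at the low end of these numbers, level with compound 1 (a 1.1-fold higher number from compound 1 to compound 2 (0.02 log units; within the scatter)) and far from compound 3 (a 13-fold higher number from compound 2 to compound 3 (1.10 log units; beyond the scatter)). Compound 3 stands equally far from compound 1 (a 13-fold higher number from compound 1 to compound 3 (1.12 log units; beyond the scatter)).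

Compound 4 `Cc1cccc(/C=C/[C@](C)(O)CC[C@@H]2[C@@]3(C)CCCC(C)(C)[C@@H]3CC[C@@]2(C)O)c1C` has not yet been measured. It differs from compound 2 by a single change (2,3-dimethylphenyl in place of 2,5-dimethylphenyl on a double-bonded chain carbon bound to a double-bonded chain carbon), with the same atoms joined differently. Within the data shown here, no measured step makes this exact move. The closest guide is the step that brought in 2,5-dimethylphenyl, which stayed within the scatter (a 1.1-fold higher number from compound 1 to compound 2 (0.02 log units; within the scatter)). The large steps involve 2,6-dimethoxyphenyl, a different group, and bear on this change only weakly. A small upward move within the scatter is therefore expected (a 1.2-fold higher number from compound 2 to compound 4 (0.08 log units; within the scatter)). Compound 4 is expected at 4000 nM with 1500 nM to 12000 nM as its estimated range.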

Compound 4, half-maximal inhibitory concentration: 3800 nM
For compound 4 the middle estimate is 1.1-fold (0.02 log units) above the measured one, and the stated range covers the measured number.
By their numbers in this assay, from the lowest: compounds 1, 2 and 4 (each within the scatter of the next); then compound 3.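

In this assay, 2,3-dimethylphenyl in place of 2,5-dimethylphenyl on the double-bonded chain carbon leaves the number within the scatter (a 1.1-fold higher number from compound 2 to compound 4 (0.06 log units; within the scatter)), so for these two compounds the rearranged methyl groups make no measurable difference. The new group also stays level with the unsubstituted phenyl (a 1.2-fold higher number from compound 1 to compound 4 (0.08 log units; within the scatter)), while 2,6-dimethoxyphenyl remains apart (an 11-fold lower number from compound 3 to compound 4 (1.04 log units; beyond the scatter)), leaving compound 3 as the only one of the four outside the level group. No evidence is available to explain this difference between the aryl groups.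

The compounds shown cannot tell whether the large steps belong to the methoxy groups or to their arrangement in 2,6-dimethoxyphenyl, since none of them has methyl groups arranged that way or methoxy groups arranged any other way. They also leave open how this position would respond to an aryl group carrying an amine or a carboxylic acid.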